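The source may report more compounds than this note shows. Statements on the series, on what has been measured and on what is new or still open speak of the compounds shown alone.

Two compounds, built on a shared core, have been measured in a functional assay on SF-539 cells (Homo sapiens) for inhibition, read by sulforhodamine B assay, with a stated time of 48 h; a lower number here means a stronger inhibitor of growth, a higher number a weaker inhibitor of growth. Compound 1 `O=C(Nc1cccc(-n2cc(-c3ccncc3)c(-c3ccc(Cl)c(O)c3)n2)c1)Nc1cccc(C(F)(F)F)c1` gives 3540 nM. Compound 2 `COc1cc(-c2nn(-c3cccc(NC(=O)Nc4ccc(Cl)c(Cl)c4)c3)cc2-c2ccncc2)ccc1Cl` gives 965 nM, the lower of the two numbers, and its gap to compound 1 lies beyond the scatter. Compound 3 `O=C(Nc1cccc(-n2cc(-c3ccncc3)c(-c3ccc(Cl)c(O)c3)n2)c1)Nc1ccc(Cl)c(Cl)c1` differs from compound 2 in one place: hydrogen in place of methyl on an oxygen on an aromatic ring. Among the compounds with values here, no measured pair shows this change on its own, so the step can only be judged by expectation. Compound 3 is estimated to come out at 1500 nM, within a range of 500 nM to 4500 nM, the expected step being a 1.6-fold higher number from compound 2 to compound 3 (0.19 log units; within the scatter), a small shift that may stay within the scatter.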

Compound 3, concentration for 50% growth inhibition: 1340 nM
For compound 3 the middle estimate is 1.1-fold (0.05 log units) above the measured one; the measured number falls inside the stated range.
By their numbers in this assay, from the lowest: compounds 2 and 3 (each within the scatter of the next); then compound 1.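

In this assay, replacing methoxy with hydroxy on the aromatic ring gives a 1.4-fold higher number from compound 2 to compound 3 (0.14 log units; within the scatter), so removing this methyl leaves no readable change in growth inhibition. With the hydroxy group kept, placing 3,4-dichlorophenyl in place of 3-(trifluoromethyl)phenyl on the amide-type nitrogen gives a 2.6-fold lower number from compound 1 to compound 3 (0.42 log units; beyond the scatter), a modest but real step. Nothing shown explains either result. On these data alone, it remains open whether a longer chain on that oxygen, or an amine in place of the hydroxy group, would keep this level of inhibition. The methoxy partner of compound 1 would show whether the methoxy-to-hydroxy result also holds with 3-(trifluoromethyl)phenyl.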